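The compounds below may be only part of what the source reports. "The series", "measured", "known", "first", "only" and "open" are said of these compounds alone.

Measured in an ADME assay on MT4 cells (Homo sapiens) for cytotoxicity, read by MTT assay, with a stated time of 96 h; a lower number here means that less compound is tolerated, a higher number that more compound is tolerated:
compound 1, `Cn1c(-c2ccc(NC(=O)CN3CCN(c4ccccc4)CC3)cc2)nc2cc(C(F)(F)F)ccc21`: 1500 nM
compound 2, `COc1cc(OC)cc(-c2nc3cc(C(F)(F)F)ccc3[nH]2)c1`: 19000 nM

Of these two numbers, compound 2 at 19000 nM stands highest; compound 1 gives the lower number, and the gap between the two lies beyond the scatter. Among the measured compounds shown here, no pair of measured compounds differs in a single place, so nothing yet shows how far one small change moves this assay.

Compound 3, `COc1cccc(-c2nc3cc(C(F)(F)F)ccc3[nH]2)c1`, remains to be measured. Its change from compound 2 is hydrogen in place of methoxy on an aromatic carbon. For the measured compounds named here, no measured step of this kind is available for comparison. The step of a 1.3-fold lower number from compound 2 to compound 3 (0.10 log units; within the scatter) is expected to stay within the scatter, if anything toward a slightly lower number. Compound 3 is therefore expected to give about 15000 nM, with a range from 6000 nM to 40000 nM.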

Compound 3, half-maximal cytotoxic concentration: 19000 nM
Compound 3: middle estimate off by 1.3-fold (0.10 log units), on the low side; low and high end bracket the measured number.
By their numbers in this assay, from the lowest: compound 1; then compounds 2 and 3 (each within the scatter of the next).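

In this assay, hydrogen in place of methoxy on an aromatic carbon, meta to a large group and meta to a methoxy group, gives no change at the digits printed from compound 2 to compound 3 (within the scatter). Among the compounds shown here, this is the only single-place step so far, and it shows that one methoxy group at this position can leave without a shift beyond the scatter in how much compound is tolerated. No supporting data on the compounds offer an explanation for this flat step.

Going by these compounds, whether this position stays as flat with an amine, a carboxylic acid or a longer alkoxy chain remains open. Also open, on these data alone, is what happens when the remaining methoxy group of compound 3 is replaced by hydrogen, as one flat step says little about a second change on the same ring.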